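The source may report more compounds than this note shows. Statements on the series, on what has been measured and on what is new or still open speak of the compounds shown alone.

Compound 1, `Cc1cc(C)n(-c2ccc(Cl)c(C(=O)NC(=O)Nc3nc4ccc(S(=O)(=O)CCCN5CCN(C)CC5)cc4s3)c2)n1`, sits in the middle of a small set of three measured compounds in an assay on HEK293 cells for displacement of a labelled ligand from growth hormone secretagogue receptor type 1 (Homo sapiens), with a stated time of 60 min (on this read-out higher numbers stand for weaker inhibition and lower numbers for stronger inhibition), where compound 1 gives 1.3 nM. Its nearest neighbour is compound 2, `CN1CCN(CCCS(=O)(=O)c2ccc3nc(NC(=O)NC(=O)c4cc(-n5cccn5)c(Cl)cc4Cl)sc3c2)CC1`, which in this assay gives 0.31 nM, a gap beyond the scatter. The furthest is compound 3, `Cc1ccnn1-c1ccc(Cl)c(C(=O)NC(=O)Nc2nc3ccc(S(=O)(=O)C4CCN(C)CC4)cc3s2)c1`, which in this assay gives 33 nM, also beyond the scatter.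

Compound 4, `CN1CCN(CCCS(=O)(=O)c2ccc3nc(NC(=O)NC(=O)c4cc(N5CCCC5)ccc4Cl)sc3c2)CC1`, has not yet been measured. It differs from compound 1 in one place: pyrrolidin-1-yl in place of 3,5-dimethyl-1H-pyrazol-1-yl on an aromatic carbon. The group that enters sits on an aromatic carbon of a six-membered aromatic ring of carbon only, meta to a large group and para to a chloro group. Going by the values given here, no measured pair in this set shares that exchange, so there is no direct precedent to lean on.

Given that compound 1 gives 1.3 nM in this assay, the change is expected to leave the number close to where it stands, with a step of a 1.5-fold higher number from compound 1 to compound 4 (0.19 log units; within the scatter) in either direction no larger than the scatter. The estimate for compound 4 in this assay is therefore 2 nM, with a range from 0.4 nM to 10 nM.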

Compound 4, half-maximal inhibitory concentration: 0.29 nM
The estimate for compound 4 lay 6.9-fold (0.84 log units) above the measured number; measured number outside the range, below it.
By their numbers in this assay, from the lowest: compounds 4 and 2 (each within the scatter of the next); then compound 1; then compound 3.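

Replacing the aromatic 3,5-dimethyl-1H-pyrazol-1-yl with the non-aromatic pyrrolidin-1-yl gives, in this assay, a 4.5-fold lower number from compound 1 to compound 4 (0.65 log units; beyond the scatter). This first one-place step in the set shows that the number responds to the group on this aromatic carbon, meta to a large group and para to a chloro group, and that an aromatic ring in this group is not required for a low number. No supporting measurement bears on the reason for this step.

This single exchange does not separate the loss of the aromatic ring from the loss of the two methyl groups. It also leaves open how a piperidin-1-yl, a morpholin-4-yl or an open-chain dimethylamino group on the same carbon would compare with the pyrrolidin-1-yl of compound 4.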